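The source may hold more compounds than are shown below. What is called first, only, known or untested is meant among the compounds shown, and "the series" means these compounds.

Measured compounds:
- compound 2, `O=C(CCc1cccnc1)Nc1ccc(CN2C(=O)c3ccccc3C2=O)cc1`: 25 nM in an assay on isolated protein for inhibition of Nicotinamide phosphoribosyltransferase (Homo sapiens), read by mass spectrometry, with stated times of 15 min and 90 min; a lower number here means a stronger inhibitor, a higher number a weaker inhibitor
- compound 1, `Nc1ccc(CNC(=O)Nc2ccc(CN3C(=O)c4ccccc4C3=O)cc2)cn1`: 4.3 nM in this assay

Compound 2 stands highest of the two numbers in this assay; its nearest neighbour is compound 1, reached by a 5.8-fold higher number from compound 1 to compound 2 (0.76 log units; beyond the scatter). Compound 3, `O=C(/C=C/c1cccnc1)Nc1ccc(CN2C(=O)c3ccccc3C2=O)cc1`, differs from compound 2 by 2-(pyridin-3-yl)ethenyl in place of 2-(pyridin-3-yl)ethyl on a carbonyl carbon. For the measured compounds named here, no measured step bears on this change; the only measured step, a 5.8-fold higher number from compound 1 to compound 2 (0.76 log units; beyond the scatter), concerns a different part of the molecule, so it gives no guide to size or direction here. A step within the scatter is expected: compound 3 is estimated at 20 nM in this assay, range 6 nM to 65 nM, corresponding to a 1.3-fold lower number from compound 2 to compound 3 (0.10 log units; within the scatter).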

Compound 3, half-maximal inhibitory concentration: 10 nM
Estimate against measurement, compound 3: 2.0-fold (0.30 log units) above, and the stated range covers the measured number.
By their numbers in this assay, from the lowest: compound 1; then compound 3; then compound 2.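

In this assay, 2-(pyridin-3-yl)ethenyl in place of 2-(pyridin-3-yl)ethyl on a carbonyl carbon gives a 2.5-fold lower number from compound 2 to compound 3 (0.40 log units; beyond the scatter), so this position responds to a double bond in the chain even with the pyridine ring unchanged. The gain closes only part of the gap to ((6-aminopyridin-3-yl)methyl)amino, with a 2.3-fold higher number from compound 1 to compound 3 (0.37 log units; beyond the scatter) still remaining. No available data account for the effect of the double bond. Still open, as far as these compounds go, is how an alkyne or a longer chain would read on this carbonyl carbon, and whether an amine on the pyridine ring of the ethenyl chain would lower the number further.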